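The compounds below may be only part of what the source reports. "The series", "measured", "known", "first", "only" and "open" are said of these compounds alone.

Two compounds of the series carry numbers in an ADME assay on a cell-free system (plasma, Homo sapiens) for metabolic stability, with Plasma (Rattus norvegicus) as the target, read by HPLC, at pH 7.4; a higher number here means that the compound lasts longer, a lower number that the compound disappears faster. Compound 1 `CCCCC(=O)O[C@@H]1CO[C@H]2[C@@H]1OC[C@@H]2OC(=O)c1ccccc1OC(C)=O` gives 0.0198 h, and compound 2 `CC(=O)Oc1ccccc1C(=O)O[C@H]1CO[C@H]2[C@@H]1OC[C@H]2OC(=O)c1ccccc1` gives 0.055 h. Among the measured compounds shown here, on these two numbers compound 2 stands highest, with compound 1 the nearest and lower; the one measured step, a 2.8-fold higher number from compound 1 to compound 2 (0.44 log units; beyond the scatter), exchanges a single group on a carbonyl carbon and is a modest change beyond the scatter.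

Compound 3 `COc1ccc(C(=O)O[C@@H]2CO[C@H]3[C@@H]2OC[C@@H]3OC(=O)c2ccccc2OC(C)=O)cc1` is still to be measured. Against compound 2 its change is methoxy in place of hydrogen on an aromatic carbon, placed on the benzoyl ester that compound 2 carries. For the measured compounds named here, no measured step touches this aromatic ring. Going by the values given here, the only known step, a 2.8-fold higher number from compound 1 to compound 2 (0.44 log units; beyond the scatter), concerns the other ester and bears on a different kind of exchange, so it gives no direct guidance for adding methoxy. With nothing in the series pointing one way or the other, the step to compound 3 is expected to be a 1.1-fold higher number from compound 2 to compound 3 (0.04 log units; within the scatter), within the usual scatter and in no set direction. The estimate for compound 3 in this assay is 0.06 h, with a range from 0.025 h to 0.15 h.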

Compound 3, half-life: 0.0525 h
Compound 3: the middle estimate sits 1.1-fold (0.06 log units) above what was measured; measured number inside the range.
By their numbers in this assay, from the lowest: compound 1; then compounds 3 and 2 (each within the scatter of the next).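

In this assay, methoxy in place of hydrogen on an aromatic carbon, para to a large group, gives a 1.0-fold lower number from compound 2 to compound 3 (0.02 log units; within the scatter), so on the benzoyl ester this addition leaves the half-life indistinguishable from that of compound 2. The exchange of butyl for 4-methoxyphenyl on a carbonyl carbon gives a 2.7-fold higher number from compound 1 to compound 3 (0.42 log units; beyond the scatter), and the exchange of butyl for phenyl gives a 2.8-fold higher number from compound 1 to compound 2 (0.44 log units; beyond the scatter); both aromatic esters therefore stand beyond the scatter from the butyl ester, and among the three compounds none goes against this. Nothing available explains why the methoxy group leaves the number in place or why either aromatic ester differs from the butyl ester.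

The compounds shown leave open whether a different group at this place, such as an amine or a carboxylic acid, would also leave the half-life within the scatter, as a single substituent cannot define the tolerance of the position. They also leave open how far the number depends on the acetyl group of the other ester, for example on its exchange for a longer chain.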